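The source may report more compounds than this note shows. Statements on the series, on what has been measured and on what is new or still open speak of the compounds shown alone.

Three compounds of the series carry numbers in an ADME assay on THP-1 cells (Homo sapiens) for cytotoxicity, read by trypan blue exclusion, with a stated time of 48 h; a higher number here means a weaker inhibitor of growth, a lower number a stronger inhibitor of growth. Compound 1 `Cc1cc(CN2CCN(c3ccccc3)CC2)c(C)n1-c1ccc(Cl)cc1` gives 25 ug/mL. Compound 2 `Cc1cc(CNCc2ccccc2)c(C)n1-c1ccc(Cl)cc1` gives 7.2 ug/mL, and compound 3 `Cc1cc(CNCc2ccccc2)c(C)n1-c1ccc(F)cc1` gives 28 ug/mL. Among the compounds with values here, the only single-point step among the measured compounds is a 3.9-fold higher number from compound 2 to compound 3 (0.59 log units; beyond the scatter). Compound 1 stands second highest of the three numbers: its value and that of compound 3 lie within the scatter of each other, while the value of compound 2 sits lower by more than the scatter.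

Compound 4 `Cc1c(CN2CCN(c3ccccc3)CC2)cc(-c2ccc(Cl)cc2)n1-c1ccc(Cl)cc1` is not yet measured in this assay. It differs from compound 1 as follows: 4-chlorophenyl in place of methyl on an aromatic carbon. Within the data shown here, none of the measured steps bears on this change. Among the measured compounds shown here, the one step in hand exchanges fluoro for chloro on an aromatic carbon, whereas here a 4-chlorophenyl enters in place of methyl on the shared core, a change of a different kind and size. There is thus no anchor in the data for either the direction or the magnitude of the step in this assay, and the expectation is set at the value of compound 1 with a wide range on both sides. Compound 4 is expected to give about 20 ug/mL, between 7 ug/mL and 60 ug/mL. That estimate corresponds to an expected step of a 1.3-fold lower number from compound 1 to compound 4 (0.10 log units; within the scatter) in this assay.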

Compound 4, concentration for 50% growth inhibition: 294 ug/mL
Compound 4: middle estimate off by 15-fold (1.17 log units), on the low side; the measured number lies above the stated range.
By their numbers in this assay, from the lowest: compound 2; then compounds 1 and 3 (each within the scatter of the next); then compound 4.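

In this assay, placing 4-chlorophenyl instead of methyl on the aromatic carbon next to the ring nitrogen gives a 12-fold higher number from compound 1 to compound 4 (1.07 log units; beyond the scatter), the first sign that the number responds to the group held at this position, which carries methyl in all three earlier compounds. The earlier single-place change, fluoro in place of chloro on an aromatic carbon, gave a 3.9-fold higher number from compound 2 to compound 3 (0.59 log units; beyond the scatter); both changes raise the number, but they differ in place and in the groups exchanged, so they form no common trend. The new result rests on one pair, with the rest of compound 1 unchanged, and no measurement in hand accounts for the step.

As far as these compounds go, whether an ethyl, a plain phenyl or a methoxy group at this position would give a number nearer that of compound 1 or that of compound 4 stays open, as does the part played by the chlorine of the entering group. Also open, from the compounds shown here alone, is whether the same exchange on the core of compound 2 would move the number in the same direction and by a similar amount.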